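Chloro in Place of Methoxy: Estimating Compound 3

The compounds below may be only part of what the source reports. "The series", "measured", "known", "first", "only" and "open" are said of these compounds alone.

Compound 1 `Cc1c(Cl)cccc1-c1cccc(COc2ccc([C@H](CC(=O)O)c3nccn3C)cc2)c1` gives 61 nM in an assay on CHO cells for agonist activity at Free fatty acid receptor 1 (Homo sapiens), read by luminescence, with a stated time of 20 s, in the presence of a further agent that is not named here; on this read-out higher numbers stand for an effect only at larger amounts of compound and lower numbers for an effect already at smaller amounts.
Compound 2 `COc1ccccc1-c1cccc(COc2ccc([C@H](CC(=O)O)c3nccn3C)cc2)c1` gives 410 nM in this assay.

Of the two measured numbers, compound 2 stands highest, meaning its effect appears only at the larger amount. Going by the values given here, its only neighbour is compound 1, and the single step between them, a 6.7-fold higher number from compound 1 to compound 2 (0.83 log units; beyond the scatter), comes from exchanging the outer aromatic ring's substituents. Compound 3 `Cn1ccnc1[C@@H](CC(=O)O)c1ccc(OCc2cccc(-c3ccccc3Cl)c2)cc1` is the next candidate. It differs from compound 2 by chloro in place of methoxy on an aromatic carbon. Among the compounds with values here, no measured step reproduces this exact exchange, so the expectation rests on the one step available: it shows that the substituent pattern on this outer ring moves the number well beyond the scatter, and that compound 1, whose ring carries a chloro together with a methyl, gives the lower number. On that basis compound 3 is expected to move part of the way back toward compound 1, a step of a 2.7-fold lower number from compound 2 to compound 3 (0.44 log units; beyond the scatter). The estimate for compound 3 in this assay is 150 nM, with a range from 50 nM to 500 nM.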

Compound 3, half-maximal effective concentration: 43 nM
Beside the measured number, compound 3's estimate is 3.5-fold (0.54 log units) above it, and the stated range ends above it.
By their numbers in this assay, from the lowest: compounds 3 and 1 (each within the scatter of the next); then compound 2.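

In this assay, the step from methoxy to chloro on an aromatic carbon, ortho to a large group, is large: a 9.5-fold lower number from compound 2 to compound 3 (0.98 log units; beyond the scatter). The earlier step between compound 1 and compound 2 changed the whole outer ring at once, so it could not show what a single exchange at this place does; this result isolates one such exchange and shows that it alone moves the number well beyond the scatter. The second new step, a 1.4-fold lower number from compound 1 to compound 3 (0.15 log units; within the scatter), lies within the scatter, so the 2-chlorophenyl and 3-chloro-2-methylphenyl rings cannot be told apart here, and a ring carrying both a chloro and a methyl is not needed for a number in this range.

Nothing available bears on what lies behind the difference between chloro and methoxy at this place. The compounds shown leave open whether the low number belongs to chloro in particular or would also appear with fluoro, trifluoromethyl or a nitrile at the same place, and whether an amine there would give a number as high as the one seen with methoxy.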